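Pyrazolyl group to carboxy chain on the shared core

This account rests on a few compounds, and the source may have more. Where it says the series, first, only, none or still open, it means among the compounds named here.

compound 1 `O=C1/C(=C\Nc2cc(-c3ccco3)[nH]n2)C(c2ccccc2)=NN1c1ccccc1`: 13400 nM
compound 2 `O=C1/C(=C\Nc2cc(-c3ccccc3)[nH]n2)C(c2ccccc2)=NN1c1ccccc1`: 12200 nM

Both values come from a functional assay on MDA-MB-361 cells (Homo sapiens) for antiproliferative activity, read by MTT assay, with a stated time of 72 h; on this read-out lower numbers stand for stronger inhibition and higher numbers for weaker inhibition. Among the measured compounds shown here, compound 1 stands level with compound 2, the only other measured compound, within the scatter. Not yet measured is compound 3 `CSC[C@H](N/C=C1\C(=O)N(c2ccccc2)N=C1c1ccccc1)C(=O)O`, which differs from compound 1 as follows: 1-carboxy-2-(methylsulfanyl)ethyl in place of 5-(furan-2-yl)-1H-pyrazol-3-yl on an amine nitrogen. For the measured compounds named here, the only measured step is a 1.1-fold lower number from compound 1 to compound 2 (0.04 log units; within the scatter). It bears only weakly, since it swaps a group on an aromatic carbon, whereas here the whole 5-(furan-2-yl)-1H-pyrazol-3-yl leaves the amine nitrogen. No measurement covers a change at that nitrogen, so the small size of that step does not carry over with confidence. A modest move towards a higher number is expected, though with low confidence in its direction, and the estimated step is a 1.3-fold higher number from compound 1 to compound 3 (0.13 log units; within the scatter). For compound 3 the expected value is 18000 nM, with an estimated range of 7000 nM to 50000 nM.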

Compound 3, half-maximal inhibitory concentration: 14200 nM
Estimate against measurement, compound 3: 1.3-fold (0.10 log units) above; measured number inside the range.
By their numbers in this assay, from the lowest: compounds 2, 1 and 3 (each within the scatter of the next).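

On the amine nitrogen, 1-carboxy-2-(methylsulfanyl)ethyl in place of 5-(furan-2-yl)-1H-pyrazol-3-yl gives a 1.1-fold higher number from compound 1 to compound 3 (0.03 log units; within the scatter) in this assay. The earlier step touched only a group on an aromatic carbon, whereas this one shows that the whole substituent on the nitrogen, including both of its aromatic rings, can give way to a chain with no ring and one defined stereocentre while the number stays within the scatter. Nothing on hand accounts for this flat result.

Still open, from the compounds shown here alone, is whether any group on this nitrogen moves the number beyond the scatter, for example a small alkyl such as methyl or a chain ending in a primary amine. Also open, going by these compounds, is whether the methyl ester of the carboxylic acid or the opposite configuration at the stereocentre would read differently.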